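The compounds below may be only part of what the source reports. "The series", "measured", "known", "first", "only" and "open" are said of these compounds alone.

Three compounds have been measured in a functional assay on Huh-7 cells (Homo sapiens) for inhibition, read by MTT assay, with a stated time of 48 h; a higher number here means a weaker inhibitor, a lower number a stronger inhibitor:
compound 1 `COc1ccc2c(=O)c(/C=C/C(=O)Nc3cccc(C)c3)coc2c1` gives 15500 nM;
compound 3 `COc1ccc2c(=O)c(/C=C/C(=O)Nc3ccccc3Cl)coc2c1` gives 58400 nM.
For compound 2 `COc1ccc2c(=O)c(/C=C/C(=O)Nc3cccc(Cl)c3)coc2c1` only a limit of the assay is reported, > 100000 nM.

Of the two numbers shown, compound 3 carries the higher one; its nearest neighbour is compound 1, and the step is a 3.8-fold higher number from compound 1 to compound 3 (0.58 log units; beyond the scatter). Compound 2 sits at the limit (the limit of > 100000 nM in this assay, at which 1 of the 3 values shown sits); against it the shift is an at least 1.7-fold lower number from compound 2 to compound 3 (0.23 log units; that floor lies within the scatter).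

Compound 4 `COc1cccc(NC(=O)/C=C/c2coc3cc(OC)ccc3c2=O)c1` has not been measured. It differs from compound 3 in one place: 3-methoxyphenyl in place of 2-chlorophenyl on an amide-type nitrogen. Among the measured compounds shown here, two measured steps bear on this. Putting a 2-chlorophenyl in place of a 3-methylphenyl on the amide-type nitrogen gave a 3.8-fold higher number from compound 1 to compound 3 (0.58 log units; beyond the scatter); putting it in place of a 3-chlorophenyl gave an at least 1.7-fold lower number from compound 2 to compound 3 (0.23 log units; that floor lies within the scatter). For the measured compounds named here, compound 4 thus returns to a phenyl substituted in the same manner as in compound 1 and compound 2, but with a methoxy, for which no measured step exists. The step expected is a 1.9-fold lower number from compound 3 to compound 4 (0.29 log units; within the scatter), a modest lowering of the number. Compound 4 is estimated at 30000 nM, with a range from 8000 nM to 100000 nM.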

Compound 4, half-maximal inhibitory concentration: 11100 nM
Compound 4: the middle estimate sits 2.7-fold (0.43 log units) above what was measured; measured number inside the range.
By their numbers in this assay, from the lowest: compounds 4 and 1 (each within the scatter of the next); then compound 3. At a limit, above all of these: compound 2.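

In this assay, methoxy in place of methyl on the aromatic carbon is a step of a 1.4-fold lower number from compound 1 to compound 4 (0.15 log units; within the scatter), so the two groups cannot be told apart at this place. Replacing the 2-chlorophenyl on the amide-type nitrogen with 3-methoxyphenyl is a clearer change, a 5.3-fold lower number from compound 3 to compound 4 (0.72 log units; beyond the scatter), and methoxy in place of chloro on the aromatic carbon gives an at least 9.0-fold lower number from compound 2 to compound 4 (0.95 log units; beyond the scatter). That last step rests on a limit for compound 2, not a number: the limit of > 100000 nM in this assay, at which 1 of the 4 values shown sits.

On these data alone, it remains open whether an amine, a carboxylic acid or a longer chain such as ethoxy on the phenyl would keep this level. Also open, as far as these compounds go, is how an unsubstituted phenyl would compare, which would show whether methyl and methoxy lower the number or chloro raises it.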